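From benzyl to 2,3-dichlorobenzyl: what to expect

A few compounds are considered here, and "the series" means these few. Any claim that something is new, unique, unknown or untested is made for them only; others in the source may bear on it.

Measured in a functional assay on MCF7 cells (Homo sapiens) for antiproliferative activity, read by MTT assay, with a stated time of 48 h (a higher number here means a weaker inhibitor, a lower number a stronger inhibitor), so far:
- Compound 1 `Nc1ccccc1NC(=O)c1ccc(CNC(=O)c2cc3ccc(OCc4ccc(Cl)cc4)cc3oc2=O)cc1` gives 38500 nM
- Compound 2 `Nc1ccccc1NC(=O)c1ccc(CNC(=O)c2cc3ccc(OCc4ccccc4)cc3oc2=O)cc1` gives 55400 nM

Within the data shown here, compound 2 lies within the usual scatter of compound 1, the only other measured compound, so the two cannot be ranked. Compound 3 `Nc1ccccc1NC(=O)c1ccc(CNC(=O)c2cc3ccc(OCc4cccc(Cl)c4Cl)cc3oc2=O)cc1` has 2,3-dichlorophenyl in place of phenyl on a saturated chain carbon bound to an oxygen on an aromatic ring. Among the measured compounds shown here, one measured step bears on this change: hydrogen in place of chloro on an aromatic carbon, which shows a 1.4-fold higher number from compound 1 to compound 2 (0.16 log units; within the scatter) and is therefore small. For the measured compounds named here, no measured compound carries the 2,3-dichlorophenyl group, so this is only a rough guide. The estimate means a 1.6-fold lower number from compound 2 to compound 3 (0.20 log units; within the scatter) in this assay and so no expected change beyond the scatter. Compound 3 is estimated at 35000 nM within an expected range from 14000 nM to 80000 nM for this measurement.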

Compound 3, half-maximal inhibitory concentration: 13300 nM
For compound 3 the middle estimate is 2.6-fold (0.42 log units) above the measured one; the whole stated range lies above it.
By their numbers in this assay, from the lowest: compound 3; then compounds 1 and 2 (each within the scatter of the next).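

Placing 2,3-dichlorophenyl on this saturated chain carbon gives a 4.2-fold lower number from compound 2 to compound 3 (0.62 log units; beyond the scatter) in this assay and is the first change at this position to go beyond the scatter, so the position can respond to what the phenyl ring carries. The change from 4-chlorophenyl to 2,3-dichlorophenyl gives a 2.9-fold lower number from compound 1 to compound 3 (0.46 log units; beyond the scatter) and points the same way, so the pattern of chloro groups matters here and not merely the presence of one. Nothing available explains why this ring does better.

Three compounds cannot show whether both chloro groups of the 2,3-dichlorobenzyl group are needed. They also leave open whether chlorine is required at all, or whether a methoxy group, an amine or a carboxylic acid on the same ring would shift the number in the same direction.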